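A few compounds are considered here, and "the series" means these few. Any claim that something is new, unique, unknown or untested is made for them only; others in the source may bear on it.

Measured so far in an assay on cells for inhibition of sodium- and chloride-dependent glycine transporter 1 (Homo sapiens); a lower number here means that less compound is needed, a higher number that more compound is needed for the effect:
- compound 1 `COc1cc(C(F)(F)F)cc(C(F)(F)F)c1C(=O)NC1(c2ccccc2)CCCN(Cc2ccccc2)C1`: 6700 nM
- compound 2 `COc1cc(C(F)(F)F)cc(SC)c1C(=O)N[C@@]1(c2ccccc2)CCCN(C)C1`: 10 nM
- compound 3 `COc1cc(C(F)(F)F)cc(SC)c1C(=O)NC1(c2cccc(F)c2)CCCN(C)C1`: 48 nM

Compound 3 stands second highest of the three numbers; compound 2 is nearest with a lower number, a gap beyond the scatter, and compound 1 is furthest with a far higher number, also beyond the scatter. Compound 4 `COc1cc(C(F)(F)F)cc(SC)c1C(=O)NC1(c2cnccn2)CCCN(C)C1` is not yet measured. It differs from compound 3 by pyrazin-2-yl in place of 3-fluorophenyl on a saturated ring carbon. No pair differing in one place has been measured, so the size of this step is unknown; an upward step beyond the scatter in this assay is expected, since the only aryl variation shown, compound 2 against compound 3, moved the number upward. Compound 4 is expected at 200 nM, within 50 nM to 1000 nM, a step of a 4.2-fold higher number from compound 3 to compound 4 (0.62 log units; beyond the scatter).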

Compound 4, half-maximal effective concentration: 1670 nM
Compound 4: middle estimate off by 8.4-fold (0.92 log units), on the low side, outside the stated range (above it).
By their numbers in this assay, from the lowest: compound 2; then compound 3; then compound 4; then compound 1.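

In this assay, this saturated ring carbon does not tolerate every six-membered aromatic ring: pyrazin-2-yl in place of 3-fluorophenyl gives a 35-fold higher number from compound 3 to compound 4 (1.54 log units; beyond the scatter), a large step beyond the scatter. Among these compounds, this is the first single-place comparison, and it shows that the aryl group at this position can strongly shift the number. No available evidence bears on what lies behind this step.

On these data alone, how a pyridin-2-yl group, with a single ring nitrogen, would compare at this carbon remains open. So does the effect of a cyclohexyl group, which has no aromatic ring.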